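Removing the ring chloro from compound 2 in the benzylamine series

The compounds below may be only part of what the source reports. "The series", "measured", "known", "first", "only" and "open" are said of these compounds alone.

Two compounds of this series carry a measured value. Compound 1 `CNc1nc(NCc2ccc(OC(F)(F)F)cc2)cc(-c2ccccn2)n1` gives 7 nM in a functional assay on HEK293 cells for agonist activity at G-protein coupled receptor 39 (Mus musculus), read by inositol phosphate accumulation; a lower number here means that less compound is needed, a higher number that more compound is needed for the effect. Compound 2 `CNc1nc(NCc2ccc(Cl)cc2Cl)cc(-c2ccccn2)n1` gives 0.5 nM in this assay, the lowest of the two numbers; the nearest, compound 1, stands at a higher number, a gap beyond the scatter.

Compound 3 `CNc1nc(NCc2ccc(Cl)cc2)cc(-c2ccccn2)n1` is not yet measured in this assay. It differs from compound 2 in one place: hydrogen in place of chloro on an aromatic carbon, so the 2,4-dichlorophenyl becomes 4-chlorophenyl. Among the measured compounds shown here, no measured pair shows this exact change, so its size must be judged from the two values at hand. Compound 1 and compound 2 differ in more than one place, so their gap cannot be tied to the chloro alone.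

The expectation is that compound 3 needs more compound than compound 2, a step of a 5.0-fold higher number from compound 2 to compound 3 (0.70 log units; beyond the scatter) in this assay, likely of moderate size and beyond the scatter. Compound 3 is therefore estimated at 2.5 nM in this assay, within a range from 0.8 nM to 8 nM.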

Compound 3, half-maximal effective concentration: 3 nM
Compound 3: the middle estimate sits 1.2-fold (0.08 log units) below what was measured; low and high end bracket the measured number.
By their numbers in this assay, from the lowest: compound 2; then compound 3; then compound 1.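

In this assay the chloro on the aromatic carbon ortho to a large group now has a size of its own: its replacement by hydrogen gives a 6.0-fold higher number from compound 2 to compound 3 (0.78 log units; beyond the scatter) and so costs potency, which means that the second chloro of the 2,4-dichlorophenyl is not dispensable in this series. Compound 3 also links compound 1 and compound 2, whose gap could not be assigned to a single change: chloro in place of trifluoromethoxy on an aromatic carbon gives a 2.3-fold lower number from compound 1 to compound 3 (0.37 log units; beyond the scatter) and thus accounts for part of the difference, with the remainder falling to the step that restores the chloro on the 2,4-dichlorophenyl. No measurement at hand bears on why either step has the size it has.

Still open, as far as these compounds go, is whether fluoro, methyl or methoxy on that same aromatic carbon would match chloro or fall back towards hydrogen. Also open, from the compounds shown here alone, is whether the chloro would bring a step of similar size to the benzylamine that carries trifluoromethoxy, so the step is so far known in the 4-chlorophenyl setting alone.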